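Turning one ring stereocentre in a weak antagonist

A few compounds are considered here, and "the series" means these few. Any claim that something is new, unique, unknown or untested is made for them only; others in the source may bear on it.

Among the measured compounds shown here, compound 1 `C[C@]1(c2ccc(OC(F)(F)F)cc2)C[C@@](O)(c2ccccn2)CO1` is a weak antagonist: in an assay on HEK293 cells for antagonist activity at transient receptor potential cation channel subfamily V member 3 (Homo sapiens), read by FLIPR and calcium flux (on this read-out lower numbers stand for stronger inhibition and higher numbers for weaker inhibition), compound 1 gives 2460 nM, the higher of the two numbers so far. Compound 2 `O[C@H](c1ccccn1)[C@]1(c2ccc(C(F)(F)F)cc2)C[C@@H](O)C1` gives 1870 nM in this assay, within the scatter of compound 1. Compound 3 `C[C@@]1(c2ccc(OC(F)(F)F)cc2)C[C@@](O)(c2ccccn2)CO1` differs from compound 1 only in one place: the two compounds have the same atoms and bonds and differ only in configuration as drawn: 1 of 2 stereo elements differ; a stereocentre at a saturated ring carbon is drawn R in compound 1 and S in compound 3. For the measured compounds named here, no measured pair shows what such a change does here, so the expected step from compound 1 to compound 3 is a 1.2-fold higher number from compound 1 to compound 3 (0.09 log units; within the scatter), meaning no shift beyond the scatter, with a wide range either way. Compound 3 is therefore estimated at 3000 nM, between 900 nM and 10000 nM.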

Compound 3, antagonist equilibrium constant: 1120 nM
Beside the measured number, compound 3's estimate is 2.7-fold (0.43 log units) above it, within the range that was stated.
By their numbers in this assay, from the lowest: compounds 3, 2 and 1 (each within the scatter of the next, the first and the last beyond it).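

Turning this one saturated ring carbon from R to S gives a 2.2-fold lower number from compound 1 to compound 3 (0.34 log units; beyond the scatter), so in this assay the configuration drawn at this position has a modest but real effect on the number. The earlier compounds shown here could not show this, as no measured pair differed in only one place. The shift can be assigned to this stereocentre alone, and the ground for that is: the fact that compounds 1 and 3 differ only in the configuration as drawn

Open, on these data alone, is whether the second stereo element matters in the same way. Also open, as far as these compounds go, is whether an amine or a carboxylic acid on this ring carbon would show the same difference between R and S.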